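A few compounds are considered here, and "the series" means these few. Any claim that something is new, unique, unknown or untested is made for them only; others in the source may bear on it.

Measured compounds:
compound 1, `O=C(NCCO)c1cc(-c2cc(F)c(Cl)cc2Cl)n[nH]1`, giving 100 nM in an assay on isolated protein for inhibition of alkaline phosphatase, tissue-nonspecific isozyme (Homo sapiens); on this read-out lower numbers stand for stronger inhibition and higher numbers for weaker inhibition
compound 2, `O=C(NCCCO)c1cc(-c2cc(F)c(Cl)cc2Cl)n[nH]1`, giving 56 nM in this assay

For the measured compounds named here, compound 2 carries the lowest of the two numbers; its only neighbour is compound 1, and the step of a 1.8-fold lower number from compound 1 to compound 2 (0.25 log units; within the scatter) lies within the scatter, so the two compounds cannot be told apart on these data. Compound 3, `O=C(c1cc(-c2cc(F)c(Cl)cc2Cl)n[nH]1)N(CCO)CCO`, is not yet measured in this assay. It differs from compound 2 in one place: bis(2-hydroxyethyl)amino in place of (3-hydroxypropyl)amino on a carbonyl carbon. Going by the values given here, the only measured step that bears on this change is a 1.8-fold lower number from compound 1 to compound 2 (0.25 log units; within the scatter), which lengthened the hydroxy-bearing chain on the amide-type nitrogen without a shift beyond the scatter. Among the compounds with values here, no measured pair shows what happens when the amide hydrogen is replaced by a second hydroxyethyl chain, so that part of the change rests on no data. Given the small size of the related step, compound 3 is expected to stay close to compound 2, with a step of a 1.4-fold higher number from compound 2 to compound 3 (0.15 log units; within the scatter). The estimate for compound 3 in this assay is 80 nM, with a range from 25 nM to 250 nM.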

Compound 3, half-maximal inhibitory concentration: 127 nM
For compound 3 the middle estimate is 1.6-fold (0.20 log units) below the measured one; measured number inside the range.
By their numbers in this assay, from the lowest: compounds 2, 1 and 3 (each within the scatter of the next, the first and the last beyond it).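

In this assay, the amide hydrogen of compound 1 can give way to a 2-hydroxyethyl group on the amide-type nitrogen with no shift that can be told from the scatter, a 1.3-fold higher number from compound 1 to compound 3 (0.10 log units; within the scatter), so this position accepts a fully substituted nitrogen carrying bis(2-hydroxyethyl)amino on the carbonyl carbon without a clear loss against the compound with the single chain of that name. The exchange of (3-hydroxypropyl)amino for bis(2-hydroxyethyl)amino, by contrast, does register, as a 2.3-fold higher number from compound 2 to compound 3 (0.36 log units; beyond the scatter), a modest step and the first among these compounds to lie beyond the scatter, which gives this position a measurable, though small, response to the change. Nothing available on these compounds accounts for either step.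

The compounds shown leave open how a terminal amine or a carboxylic acid in place of the hydroxy group would read in this assay, and where a longer chain such as 4-hydroxybutyl would stand. They also leave open whether a plain methyl group on the amide-type nitrogen would read like the 2-hydroxyethyl group of compound 3.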